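A few compounds are considered here, and "the series" means these few. Any claim that something is new, unique, unknown or untested is made for them only; others in the source may bear on it.

In a functional assay on RAW264.7 cells (Mus musculus) for inhibition, with stated times of 2 h and 24 h (on this read-out higher numbers stand for weaker inhibition and lower numbers for stronger inhibition), compound 2 (`COc1cc(OC)cc([C@@H]2C(SCc3ccccc3)c3cc(OC)cc(OC)c3[C@H]2c2ccccc2)c1`) gives only a limit (> 200000 nM). Compound 3 (`COc1ccc([C@@H]2c3c(OC)cc(OC)cc3C(SCc3ccccc3)[C@H]2c2cc(OC)cc(OC)c2)cc1`) also gives only a limit (> 200000 nM). Among the measured compounds shown here, those two limits leave the one measured step unreadable (a step that the two limits leave unreadable from compound 2 to compound 3), so much of the evidence is simply (the limit of > 200000 nM in this assay, at which 2 of the 3 values shown sit). Compound 4 (`COc1ccc(C(O)C2c3cc(OC)cc(OC)c3[C@@H](c3ccccc3)[C@@H]2c2cc(OC)cc(OC)c2)cc1`) differs from compound 2 by hydroxy(4-methoxyphenyl)methyl in place of benzylsulfanyl on a saturated ring carbon, with hydroxy(4-methoxyphenyl)methyl in place of benzylsulfanyl on a saturated ring carbon. For the measured compounds named here, no measured step tests this swap. Going by the values given here, the only true number comes from compound 1 (`COc1cc(OC)cc([C@@H]2C(=O)c3cc(OC)cc(OC)c3[C@H]2c2ccc(F)cc2)c1`), which reaches 44800 nM and suggests that weak inhibition is the likely outcome. The expected change is modest, toward stronger inhibition if it can be read at all (an at least 1.5-fold lower number from compound 2 to compound 4 (0.18 log units; that floor lies within the scatter)). For compound 4 the estimated value is 130000 nM, with an expected range of 35000 nM to 400000 nM.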

Compound 4, half-maximal inhibitory concentration: 16500 nM
For compound 4 the middle estimate is 7.9-fold (0.90 log units) above the measured one; the whole stated range lies above it.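

In this assay, among the compounds shown here, hydroxy(4-methoxyphenyl)methyl in place of benzylsulfanyl on this saturated ring carbon gives an at least 12-fold lower number from compound 2 to compound 4 (1.08 log units; beyond the scatter), the first readable step at this position. Compound 2 gives only a limit, so this step is a floor and its true size stays unknown: the limit of > 200000 nM in this assay, at which 2 of the 4 values shown sit.

The compounds shown do not separate the roles of the hydroxy group, the methoxy group and the loss of sulfur, since all three change together. On these data alone, how an amine or a carboxylic acid on this ring carbon would compare also remains open.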